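Swapping a benzyl group for a thiourea on the core

The source may hold more compounds than are shown below. What is called first, only, known or untested is meant among the compounds shown, and "the series" means these compounds.

Compound 1, `NC(=O)c1c(NC(=O)c2ccccc2Cl)sc2c1CCN(Cc1ccccc1)C2`, gives in a functional assay on HeLa cells (Homo sapiens) for antiproliferative activity, with a stated time of 24 h (on this read-out lower numbers stand for stronger inhibition and higher numbers for weaker inhibition), the value 38400 nM.
Compound 2, `NC(=O)c1c(NC(=O)c2ccccc2Cl)sc2c1CCN(Cc1ccccc1Cl)C2`, gives in this assay the value 27500 nM.
Compound 3, `NC(=O)c1c(NC(=O)c2ccccc2Cl)sc2c1CCN(Cc1cc(Cl)cc(Cl)c1)C2`, gives in this assay the value 19600 nM.

All three compounds share one core and differ only in the group on the ring nitrogen. Compound 3 has the lowest number of the three, but its steps to the others are small: a 2.0-fold lower number from compound 1 to compound 3 (0.29 log units; within the scatter) and a 1.4-fold lower number from compound 2 to compound 3 (0.15 log units; within the scatter), and between the first two a 1.4-fold lower number from compound 1 to compound 2 (0.14 log units; within the scatter). None of these changes is more than the scatter of repeated measurements, so the three compounds cannot be told apart on the numbers shown.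

Compound 4, `NC(=O)c1c(NC(=O)c2ccccc2Cl)sc2c1CCN(C(=S)Nc1ccccc1F)C2`, carries a group of 10 heavy atoms (7 carbon, 1 nitrogen, 1 fluorine, 1 sulfur; one six-membered aromatic ring of carbon only) in place of a group of 9 heavy atoms (7 carbon, 2 chlorine; one six-membered aromatic ring of carbon only), on an amine nitrogen in a ring. The measured steps only ever changed chloro substituents on an aromatic ring of a benzyl group; none of them replaced the benzyl group itself with a thiourea, so they bear on this change only weakly. Since every measured step stayed within the scatter, the expectation for compound 4 in this assay is a value of 20000 nM, between 5000 nM and 80000 nM. Among the measured compounds shown here, this estimate means a step of a 1.0-fold higher number from compound 3 to compound 4 (0.01 log units; within the scatter), expected to stay within the scatter, with the range kept wide because the change has no measured counterpart.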

Compound 4, half-maximal inhibitory concentration: 28700 nM
The estimate for compound 4 lay 1.4-fold (0.16 log units) below the measured number, and the stated range covers the measured number.
By their numbers in this assay, from the lowest: compounds 3, 2, 4 and 1 (each within the scatter of the next).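

Compounds 1 to 3 varied only the chloro substituents on a benzyl group, whereas compound 4 replaces the benzyl group itself with a thiourea-linked fluorophenyl group, which adds a hydrogen-bond donor and a hydrogen-bond acceptor. In this assay, the result is a 1.5-fold higher number from compound 3 to compound 4 (0.17 log units; within the scatter), a 1.0-fold higher number from compound 2 to compound 4 (0.02 log units; within the scatter) and a 1.3-fold lower number from compound 1 to compound 4 (0.13 log units; within the scatter), so on this amine nitrogen in a ring, even a change of linking group leaves compound 4 indistinguishable from the three benzyl compounds. No supporting data are available to explain this result.

From the compounds shown here alone, it remains open whether any group on this nitrogen can produce a step beyond the scatter, such as a urea with oxygen in place of the sulfur, a carboxylic acid or a longer alkyl chain. Going by these compounds, the part played by the fluorine also remains open, as an unsubstituted phenyl thiourea would be needed to isolate it.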